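Methoxy in place of acetyl on the shared core

The source may hold more compounds than are shown below. What is called first, only, known or untested is meant among the compounds shown, and "the series" means these compounds.

Compound 1, `CCOc1ccccc1OC(C)C1=NCCN1`: 0.5
Compound 2, `CC(=O)c1ccccc1OC(C)C1=NCCN1`: 0.6

In an assay on CHO cells with Alpha-2B adrenergic receptor (Homo sapiens) as the target (on this read-out higher numbers stand for larger maximal responses and lower numbers for smaller maximal responses), compound 1 gives 0.5, and compound 2 gives 0.6. Compound 2 sits at the top of these two numbers, but the step a number 0.10 higher from compound 1 to compound 2 (within the scatter) lies within the scatter, so the two compounds are not told apart by this read-out.

Compound 3, `COc1ccccc1OC(C)C1=NCCN1`, has not yet been measured. It differs from compound 2 in one place: methoxy in place of acetyl on an aromatic carbon. Going by the values given here, the only measured step that bears on this change is the exchange of ethoxy for acetyl at the same place, a number 0.10 higher from compound 1 to compound 2 (within the scatter), which stayed within the scatter. A further exchange of acetyl for methoxy at that place is therefore expected to shift the number little, if at all, so the step a number 0.10 lower from compound 2 to compound 3 (within the scatter) is estimated to stay within the scatter. Compound 3 is expected to give 0.5, in a range from 0.35 to 0.65.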

Compound 3, intrinsic activity: the largest response reached, as a fraction of the reference agonist's: 0.5
Compound 3: the middle estimate sits on the measured number at the digits printed; measured number inside the range.
By their numbers in this assay, from the lowest: compounds 1, 3 and 2 (each within the scatter of the next).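

Methoxy now joins ethoxy and acetyl as a third group tested at this place on the aromatic ring, and in this assay the exchange of acetyl for methoxy gives a number 0.10 lower from compound 2 to compound 3 (within the scatter). Removing the end methyl of the ethoxy chain, which turns ethoxy into methoxy, gives no change at the digits printed from compound 1 to compound 3 (within the scatter), so the numbers do not tell the three groups apart, whether the atom joined to the ring belongs to an ether or a carbonyl. No evidence is available that accounts for these numbers.

Still open, as far as these compounds go, is whether a group of a different kind at this place, such as an amine, a carboxylic acid or a longer chain, would stand clear of the scatter. Also open, from the compounds shown here alone, is what a plain hydrogen there would give in this assay.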